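Chloro to Bromo: Expected Tolerance in the Cell Assay

A few compounds are considered here, and "the series" means these few. Any claim that something is new, unique, unknown or untested is made for them only; others in the source may bear on it.

Of the compounds shown here, two sharing one core have been tested in an ADME assay on RD cells (Homo sapiens) for cytotoxicity; a lower number here means that less compound is tolerated, a higher number that more compound is tolerated. Compound 1 `O=C1Nc2ccc(OC(F)(F)F)cc2/C1=N/NC(=S)Nc1ccccc1` carries a trifluoromethoxy group on the core. In this assay compound 1 gives > 25000 nM, which is a limit of the assay rather than a number. Compound 2 `O=C1Nc2ccccc2/C1=N/NC(=S)Nc1ccc(Cl)cc1` carries a chloro group on its outer ring instead. In this assay compound 2 gives > 25000 nM, again a limit of the assay and not a measured number. For the measured compounds named here, compound 2 therefore stands exactly where the only other value stands: the limit of > 25000 nM in this assay, at which 2 of the 2 values shown sit. Going by the values given here, no step between measured compounds can be read from two limits, so no size of change is known from the data.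

Compound 3 `O=C1Nc2ccccc2/C1=N/NC(=S)Nc1ccc(Br)cc1` is not yet measured. Compared with compound 2 it differs as follows: bromo in place of chloro on an aromatic carbon. With both known values sitting at the limit, the expected step is a step that the limit leaves unreadable from compound 2 to compound 3, nothing beyond the usual scatter. Compound 3 is estimated at 30000 nM, with a range from 15000 nM to 60000 nM, and most likely it will again be reported as a limit.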

Compound 3, half-maximal cytotoxic concentration: > 25000 nM
Compound 3: no number, only a limit; the forecaster's own chance of this, stated with the estimate: 85%; the middle value is on the limit's open side.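

In this assay compound 3 gives > 25000 nM which is a limit of the assay and not a number. For the compounds shown here, compound 2 and compound 3 both sit at a limit, so no step between them can be read. The compounds shown leave open what concentration of any of them would harm the cells, and whether chloro and bromo differ there at all.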